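A few compounds are considered here, and "the series" means these few. Any claim that something is new, unique, unknown or untested is made for them only; others in the source may bear on it.

Compound 1 `O=C(Nc1ccc(Cl)c(-c2nnc3c(Cl)cccn23)c1)c1ccccc1Cl`: 59900 nM
Compound 2 `O=C(Nc1ccc(Cl)c(-c2nnc3c(Cl)cccn23)c1)c1ccc(Cl)cc1`: > 100000 nM
Compound 3 `O=C(Nc1ccc(Cl)c(-c2nnc3c(Cl)cccn23)c1)c1ccc(Cl)cc1Cl`: > 100000 nM

All three share one core and differ only in the aromatic group on the carbonyl carbon. In a functional assay on MDA-MB-231 cells (Homo sapiens) for antiproliferative activity, read by MTT assay, with stated times of 72 h and 4 h (a higher number here means a weaker inhibitor, a lower number a stronger inhibitor), compound 1 gives 59900 nM. For compound 2 the assay reports only a limit, > 100000 nM. For compound 3 it likewise reports only a limit, > 100000 nM, so compound 3 stands at a limit and not at a number (the limit of > 100000 nM in this assay, at which 2 of the 3 values shown sit). The change to compound 4 `O=C(Nc1ccc(Cl)c(-c2nnc3c(Cl)cccn23)c1)c1cccnc1Cl` is 2-chloropyridin-3-yl in place of 2,4-dichlorophenyl on a carbonyl carbon. Within the data shown here, no measured step exchanges a ring carbon for a ring nitrogen; the steps of an at least 1.6-fold higher number from compound 1 to compound 3 (0.22 log units; that floor lies within the scatter) and a step that the two limits leave unreadable from compound 2 to compound 3 concern the same position, and neither is readable beyond the scatter. Compound 4 is therefore expected to stay near the limit, with no step beyond the scatter: an at least 1.2-fold lower number from compound 3 to compound 4 (0.09 log units; that floor lies within the scatter). The estimate for compound 4 is 80000 nM, between 30000 nM and 200000 nM.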

Compound 4, half-maximal inhibitory concentration: 89700 nM
Beside the measured number, compound 4's estimate is 1.1-fold (0.05 log units) below it; low and high end bracket the measured number.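

A ring nitrogen in the group on this carbonyl carbon still gives a readable number in this assay, and exchanging 2-chlorophenyl for 2-chloropyridin-3-yl makes no difference that can be told apart: a 1.5-fold higher number from compound 1 to compound 4 (0.18 log units; within the scatter). Against the other two compounds only floors can be read, an at least 1.1-fold lower number from compound 3 to compound 4 (0.04 log units; that floor lies within the scatter) and an at least 1.1-fold lower number from compound 2 to compound 4 (0.04 log units; that floor lies within the scatter), so neither step shows a real change. Compound 2 and compound 3 remain limits, not numbers: the limit of > 100000 nM in this assay, at which 2 of the 4 values shown sit.

As far as these compounds go, whether any group here can move the number beyond the scatter stays open. So does the effect of an amine or a carboxylic acid on this ring.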